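One Aromatic Group Swapped on a Reductase Inhibitor Core

The source may hold more compounds than are shown below. What is called first, only, known or untested is meant among the compounds shown, and "the series" means these compounds.

Compound 1: `CC(C)c1sc(-c2ccccc2)c(C2CCCC2)c1/C=C/[C@@H](O)C[C@@H](O)CC(=O)O` — 417 nM
Compound 2: `CC(C)c1sc(-c2ccccc2)c(C2CCCCC2)c1/C=C/[C@@H](O)C[C@@H](O)CC(=O)O` — 202 nM
Compound 3: `CC(C)c1sc(-c2ccccc2)c(-c2cccc(C(F)(F)F)c2)c1/C=C/[C@@H](O)C[C@@H](O)CC(=O)O` — 2980 nM

In an assay on microsomes for inhibition of 3-hydroxy-3-methylglutaryl-coenzyme A reductase (Rattus norvegicus) (on this read-out lower numbers stand for stronger inhibition and higher numbers for weaker inhibition), compound 3 stands highest of the three numbers, so it is the weakest inhibitor shown. The two steps that lead to it, a 7.1-fold higher number from compound 1 to compound 3 (0.85 log units; beyond the scatter) and a 15-fold higher number from compound 2 to compound 3 (1.17 log units; beyond the scatter), both replace a saturated ring with an aromatic one, and both raise the number clearly. Compound 4, `COc1ccc(-c2c(-c3ccccc3)sc(C(C)C)c2/C=C/[C@@H](O)C[C@@H](O)CC(=O)O)cc1`, keeps an aromatic group but changes it: 4-methoxyphenyl in place of 3-(trifluoromethyl)phenyl on an aromatic carbon. Within the data shown here, no measured step exchanges one aromatic group for another, so these data only show that the aromatic group in compound 3 goes with weak inhibition. Compound 4 is therefore expected to stay near compound 3, with an estimated step of a 1.4-fold lower number from compound 3 to compound 4 (0.13 log units; within the scatter), within or barely beyond the scatter. Compound 4 is estimated at 2200 nM, between 700 nM and 7000 nM.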

Compound 4, half-maximal inhibitory concentration: 2430 nM
Beside the measured number, compound 4's estimate is 1.1-fold (0.04 log units) below it; measured number inside the range.
By their numbers in this assay, from the lowest: compound 2; then compound 1; then compounds 4 and 3 (each within the scatter of the next).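

Swapping one aromatic group for another at this position leaves the number within the scatter (a 1.2-fold lower number from compound 3 to compound 4 (0.09 log units; within the scatter)), even though 3-(trifluoromethyl)phenyl and 4-methoxyphenyl carry different substituents. Compound 4 also stands clearly apart from both saturated rings (a 12-fold higher number from compound 2 to compound 4 (1.08 log units; beyond the scatter); a 5.8-fold higher number from compound 1 to compound 4 (0.77 log units; beyond the scatter)), so the weak inhibition seen with compound 3 is not confined to its 3-(trifluoromethyl)phenyl group. No available measurement explains this gap. Still open, going by these compounds, is whether an unsubstituted phenyl, a pyridine ring or an open chain such as butyl would resemble the aromatic groups or the saturated rings here.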